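Notes on the aryl swap from compound 2 to compound 3

A few compounds are considered here, and "the series" means these few. Any claim that something is new, unique, unknown or untested is made for them only; others in the source may bear on it.

Compound 2 `COc1ccc(O)c(/C=N/NC(=O)CSc2nnnn2-c2cccc3ccccc23)c1` stands at the lower end of the pair measured so far in an ADME assay on MT4 cells (Homo sapiens) for cytotoxicity, read by MTT assay (on this read-out higher numbers stand for lower toxicity in this test and lower numbers for higher toxicity in this test), giving 4510 nM. Within the data shown here, compound 1 `O=C(CSc1nnnn1-c1cccc2ccccc12)N/N=C/c1ccccc1Cl` gives 69700 nM in this assay, and the single change between them, 2-hydroxy-5-methoxyphenyl in place of 2-chlorophenyl on a carbon with a double bond to nitrogen, brought a 15-fold lower number from compound 1 to compound 2 (1.19 log units; beyond the scatter). Compound 3 `O=C(CSc1nnnn1-c1cccc2ccccc12)N/N=C/c1cccc(O)c1` is not yet measured; it differs from compound 2 by 3-hydroxyphenyl in place of 2-hydroxy-5-methoxyphenyl on a carbon with a double bond to nitrogen. Among the measured compounds shown here, the only step that bears on this change is the one from compound 1 to compound 2, which swapped the same aryl group on the same carbon and was large; compound 3 keeps one hydroxyl but loses the methoxy, so a number between the two measured values is expected. Compound 3 is therefore estimated at 20000 nM in this assay, within 5000 nM to 80000 nM, an expected step of a 4.4-fold higher number from compound 2 to compound 3 (0.65 log units; beyond the scatter).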

Compound 3, half-maximal cytotoxic concentration: 169000 nM
Beside the measured number, compound 3's estimate is 8.5-fold (0.93 log units) below it; measured number outside the range, above it.
By their numbers in this assay, from the lowest: compound 2; then compound 1; then compound 3.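

In this assay, the aryl group on a carbon with a double bond to nitrogen now covers a wider span than the first pair showed: 3-hydroxyphenyl in place of 2-hydroxy-5-methoxyphenyl gives a 37-fold higher number from compound 2 to compound 3 (1.57 log units; beyond the scatter), so a hydroxyl on the ring does not by itself go with the low number of compound 2. 3-hydroxyphenyl in place of 2-chlorophenyl gives a 2.4-fold higher number from compound 1 to compound 3 (0.38 log units; beyond the scatter), a modest step that leaves compound 3, not compound 1, with the highest number of the three. Nothing on hand accounts for either step.

As far as these compounds go, the aryl groups of compound 2 and compound 3 differ both in the methoxy and in where the hydroxyl sits, and the share of each in the step remains open. Also open, from the compounds shown here alone, is how an amine or a carboxylic acid on this aryl ring would read in this assay.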